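The source may report more compounds than this note shows. Statements on the series, on what has been measured and on what is new or still open speak of the compounds shown alone.

Measured in a functional assay on HepG2 cells (Homo sapiens) for inhibition, read by CCK-8 assay, with a stated time of 48 h (on this read-out lower numbers stand for stronger inhibition of growth and higher numbers for weaker inhibition of growth), so far
compound 1 `O=C(CCCSC[C@H](NC(=O)OCc1ccccc1)C(=O)Nc1ccccc1)NO` gives 7300 nM
compound 2 `O=C(CCCSC[C@H](NC(=O)OCc1ccccc1)C(=O)Nc1cccc2ccccc12)NO` gives 4500 nM

Compound 1 at 7300 nM stands level with compound 2, within the scatter, and the series holds no third number yet. Compound 3 `O=C(CCCSC[C@H](NC(=O)c1ccccc1)C(=O)Nc1ccccc1)NO` keeps the rest of compound 1 and carries phenyl in place of benzyloxy on a carbonyl carbon. Within the data shown here, the only measured step (a 1.6-fold lower number from compound 1 to compound 2 (0.21 log units; within the scatter)) lies on an amide-type nitrogen and not at this place, so compound 2 offers a weak guide and no direction. In this assay no shift beyond the scatter is therefore expected. The expected step (a 1.1-fold higher number from compound 1 to compound 3 (0.04 log units; within the scatter)) stays within the scatter. Compound 3 is estimated at 8000 nM with an expected range from 3000 nM to 20000 nM for now.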

Compound 3, concentration for 50% growth inhibition: 6200 nM
Compound 3: the middle estimate sits 1.3-fold (0.11 log units) above what was measured; measured number inside the range.
By their numbers in this assay, from the lowest: compounds 2, 3 and 1 (each within the scatter of the next).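

Among these compounds, at this carbonyl carbon, phenyl in place of benzyloxy gives a 1.2-fold lower number from compound 1 to compound 3 (0.07 log units; within the scatter) in this assay and so provides the first reading at this place, as the earlier step lay on an amide-type nitrogen. The change from benzyloxycarbonyl to benzoyl takes the group from 8 heavy atoms to 6 and from 1 hydrogen-bond acceptor to 0, and the number stays within the scatter. Only these two aromatic groups have been read here, so the tolerance of this place beyond them is still undefined.

No measurement shown here bears on the reason for this result.

Going by these compounds, whether an aliphatic group such as tert-butoxy or methyl, or a basic amine, at this carbonyl carbon would shift the number beyond the scatter remains open. Also open, on these data alone, is how benzoyl behaves when paired with naphthalen-1-yl on the amide-type nitrogen.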